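Cyclobutyl Replacing Propyl on the Ring Amide Nitrogen

A few compounds are considered here, and "the series" means these few. Any claim that something is new, unique, unknown or untested is made for them only; others in the source may bear on it.

Measured compounds:
compound 1 `O=C(O)c1cc(-c2cccc(COc3ccc4c(c3)CN(Cc3ccc(C(F)(F)F)cc3)C4=O)c2)ccc1Cl` gives 350 nM
compound 2 `O=C(O)c1cc(-c2cccc(COc3ccc4c(c3)CN(C3CCCCC3)C4=O)c2)ccc1Cl` gives 270 nM
compound 3 `CCCN1Cc2cc(OCc3cccc(-c4ccc(Cl)c(C(=O)O)c4)c3)ccc2C1=O` gives > 10000 nM

These three compounds share one core and differ only in the group on the amide-type nitrogen in the ring, and they were tested in an assay on HEK293 cells for positive allosteric modulation of metabotropic glutamate receptor 2 (Rattus norvegicus), read by thallium flux; a lower number here means that less compound is needed, a higher number that more compound is needed for the effect. Compound 1 carries a 4-(trifluoromethyl)benzyl group there, compound 2 a cyclohexyl group, and the step of a 1.3-fold lower number from compound 1 to compound 2 (0.11 log units; within the scatter) shows the two values lying together. Compound 3, with a propyl group, gives only a limit in this assay, > 10000 nM (the limit of > 10000 nM in this assay, at which 1 of the 3 values shown sits). It stands at the bottom of the series: the step of an at least 37-fold higher number from compound 2 to compound 3 (1.56 log units; beyond the scatter) and the step of an at least 28-fold higher number from compound 1 to compound 3 (1.45 log units; beyond the scatter) are both large.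

Compound 4 `O=C(O)c1cc(-c2cccc(COc3ccc4c(c3)CN(C3CCC3)C4=O)c2)ccc1Cl` is not yet measured. It differs from compound 3 by cyclobutyl in place of propyl on an amide-type nitrogen in a ring. Of the measured steps, the step of an at least 37-fold higher number from compound 2 to compound 3 (1.56 log units; beyond the scatter) bears most directly on it, since cyclobutyl is again a ring on that nitrogen, like the cyclohexyl of compound 2, though a four-membered one. Compound 4 is therefore expected to give a lower number than compound 3 in this assay, with the step of an at least 4.0-fold lower number from compound 3 to compound 4 (0.60 log units; beyond the scatter) expected, though compound 3 is only a limit and the size is uncertain. The estimate for compound 4 is 2500 nM, between 600 nM and 10000 nM.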

Compound 4, half-maximal effective concentration: 90 nM
For compound 4 the middle estimate is 28-fold (1.44 log units) above the measured one; the whole stated range lies above it.
By their numbers in this assay, from the lowest: compound 4; then compounds 2 and 1 (each within the scatter of the next). At a limit, above all of these: compound 3.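

Going from propyl, with 3 heavy atoms, to cyclobutyl, with 4 heavy atoms, gives an at least 110-fold lower number from compound 3 to compound 4 (2.04 log units; beyond the scatter) in this assay, which shows that a small group on this nitrogen is not in itself a poor one. Nor is a large group required, as cyclobutyl also gives a 3.0-fold lower number from compound 2 to compound 4 (0.48 log units; beyond the scatter) and a 3.9-fold lower number from compound 1 to compound 4 (0.59 log units; beyond the scatter). The first of these steps gives only a minimum size, as compound 3 has a limit and not a number: the limit of > 10000 nM in this assay, at which 1 of the 4 values shown sits.

The compounds shown leave open whether the closed ring is what matters, a question that isopropyl, a small open chain, and cyclopropyl, a still smaller ring, could help to settle. Also open is how cyclopentyl would fall among these rings, and whether a four-membered ring holding an oxygen, such as oxetanyl, would serve as well as cyclobutyl.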